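The compounds below may be only part of what the source reports. "The series", "measured", "known", "first", "only" and "open" are said of these compounds alone.

Values in a functional assay on U-87MG ATCC cells (Homo sapiens) for cytotoxicity, read by MTT assay, with a stated time of 48 h (on this read-out higher numbers stand for weaker inhibition and lower numbers for stronger inhibition), so far:
- compound 1 `CC(=NNC(=S)Nc1ccccc1[N+](=O)[O-])c1ccccn1` gives 4.3 nM
- compound 2 `CC(=NNC(=S)Nc1ccccc1)c1ccccn1` gives 1.4 nM

Compound 2, at 1.4 nM, holds the lower of the two numbers. Compound 3 `CC(=NNC(=S)Nc1ccccc1I)c1ccccn1` differs from it by iodo in place of hydrogen on an aromatic carbon, ortho to a large group. Among the compounds with values here, one measured step bears on this: a 3.1-fold lower number from compound 1 to compound 2 (0.49 log units; beyond the scatter), where hydrogen replaces nitro, a modest change beyond the scatter. On that single step, a modest rise is expected in this assay on going from hydrogen to iodo. The expected change is a 1.8-fold higher number from compound 2 to compound 3 (0.25 log units; within the scatter) in this estimate. Compound 3 is estimated at 2.5 nM, with an expected range from 0.8 nM to 8 nM in this read-out.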

Compound 3, half-maximal inhibitory concentration: 6.1 nM
For compound 3 the middle estimate is 2.4-fold (0.39 log units) below the measured one; measured number inside the range.
By their numbers in this assay, from the lowest: compound 2; then compounds 1 and 3 (each within the scatter of the next).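

In this assay, iodo now joins nitro as a second group that, at this place ortho to a large group, gives a higher number than hydrogen: a 4.4-fold higher number from compound 2 to compound 3 (0.64 log units; beyond the scatter). Iodo and nitro do not separate, with a 1.4-fold higher number from compound 1 to compound 3 (0.15 log units; within the scatter), so two different replacements of hydrogen land within the scatter of each other. Nothing available explains this shared loss against hydrogen. Open, as far as these compounds go, is whether fluoro, methyl or an amine at this place would stay with hydrogen or fall with iodo and nitro. Also open, from the compounds shown here alone, is whether iodo elsewhere on this ring would give the same step.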